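Half-life of chloromethyl ketone analogue within the thymidine series

The source may hold more compounds than are shown below. What is called first, only, known or untested is meant among the compounds shown, and "the series" means these compounds.

Of the compounds shown here, three of one shared core have been measured in an ADME assay for pharmacokinetics; a lower number here means that the compound disappears faster, a higher number that the compound lasts longer. Compound 1 `Cc1cn(C2CC(O)C(CCC(=O)CI)O2)c(=O)[nH]c1=O` gives 4 h, and compound 2 `Cc1cn(C2CC(O)C(C(=O)Nc3ccc(C(=O)CBr)cc3)O2)c(=O)[nH]c1=O` gives 4 h in this assay, the two standing level at the digits recorded, together the highest pair of the three numbers. Compound 3 `Cc1cn(C2CC(O)C(CNC(=O)c3ccc(C(=O)CBr)cc3)O2)c(=O)[nH]c1=O` gives 1 h in this assay, a step down from compound 1 that lies beyond the scatter of repeated measurement; the two structures differ in more than one place, so this gap is noted only as the two values show it.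

Compound 4 `Cc1cn(C2CC(O)C(CCC(=O)CCl)O2)c(=O)[nH]c1=O` remains to be measured. It differs from compound 1 in one place, (chloro in place of iodo on a saturated chain carbon bound to a carbonyl carbon).

For the measured compounds named here, no measured pair covers this exchange, so there is no step on which to rest a direction. Compound 1 and compound 2 already hold the longer half-lives seen here, and the change from iodo to chloro is small in what it counts. The expectation for the half-life in this assay is therefore a step from compound 1 to compound 4 of a 1.5-fold higher number from compound 1 to compound 4 (0.18 log units; within the scatter), a modest rise that may not clear the scatter. Compound 4 is estimated to give 6 h in this assay, within a range from 3 h to 12 h.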

Compound 4, half-life: > 52 h
Compound 4: only a limit was reported (the forecaster's own chance of this, stated with the estimate: 5%); middle value at least 8.6-fold (0.93 log units) away from the limit.
By their numbers in this assay, from the lowest: compound 3; then compounds 1 and 2 (each within the scatter of the next). At a limit, above all of these: compound 4.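

In this assay the series now has its first single-place step: with chloro in place of iodo on a saturated chain carbon bound to a carbonyl carbon, the read-out moves by an at least 13-fold higher number from compound 1 to compound 4 (1.11 log units; beyond the scatter). The exchange leaves the counts of rings, hydrogen-bond donors, hydrogen-bond acceptors and net charge unchanged, yet the half-life at this position turns on which halogen sits there, something compounds 1, 2 and 3, which differ from one another in more than one place, did not show. Compound 4 gives > 52 h, a limit of the assay and not a number, and the full size of the step stays unread because of it: the limit of > 52 h in this assay, at which 1 of the 4 values shown sits.

Open, on these data alone, is whether the half-life follows the halogen alone, which fluoro or a hydroxyl group on the same saturated chain carbon would begin to test. Also open, as far as these compounds go, is whether chloro in place of bromo would give a step of like size in compound 2 and compound 3.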